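Dimethylamino to diethylamino on the amide side chain

This account rests on a few compounds, and the source may have more. Where it says the series, first, only, none or still open, it means among the compounds named here.

Measured compounds:
compound 1 `COc1ccc(-c2cc3ccc(OC)cc3nc2Nc2ccc(NC(=O)CN3CCCC3)cc2)cc1`: 6600 nM
compound 2 `COc1ccc(-c2cc3cc(OC)ccc3nc2Nc2ccc(NC(=O)CN(C)C)cc2)cc1`: 39500 nM

In a functional assay on MCF7 cells (Homo sapiens) for antiproliferative activity, read by MTT assay, with a stated time of 48 h (a higher number here means a weaker inhibitor, a lower number a stronger inhibitor), compound 1 gives 6600 nM. In this assay compound 2 gives 39500 nM, the higher of the two numbers, and the gap between compound 1 and compound 2 lies beyond the usual scatter. The two compounds differ in more than one place. Which of those differences the gap follows is not shown by these two values.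

Compound 3 `CCN(CC)CC(=O)Nc1ccc(Nc2nc3ccc(OC)cc3cc2-c2ccc(OC)cc2)cc1` is not yet measured. It differs from compound 2 in one place: diethylamino in place of dimethylamino on a saturated chain carbon bound to a carbonyl carbon. Among the measured compounds shown here, no measured pair shows this change on its own, so its effect has to be guessed. With two carbons added to the terminal amine and no change in donor or acceptor count, the step is expected to be small; a modest move toward a lower number is plausible, but a step within the scatter is at least as likely. The expected step from compound 2 to compound 3 is a 1.6-fold lower number from compound 2 to compound 3 (0.20 log units; within the scatter). Compound 3 is therefore estimated at 25000 nM, in a range from 8000 nM to 60000 nM.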

Compound 3, half-maximal inhibitory concentration: > 50000 nM
Compound 3: no number, only a limit (the forecaster's own chance of this, stated with the estimate: 10%); middle value at least 2.0-fold (0.30 log units) from the limit.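

In this assay compound 3 gives a limit of the assay and not a number: > 50000 nM. Among the compounds shown here, the swap of dimethylamino for diethylamino on a saturated chain carbon bound to a carbonyl carbon, read here on its own for the first time, gives an at least 1.2-fold higher number from compound 2 to compound 3 (0.10 log units; that floor lies within the scatter), so this change does not move the series toward a lower number at this position, and the larger terminal amine brings no visible gain in this pair. Only a floor can be stated for this step, and that floor cannot settle whether the change truly weakens the compound, because the reading for compound 3 stops at the limit: the limit of > 50000 nM in this assay, at which 1 of the 3 values shown sits.

The effect of the amine in compound 1 remains unresolved, since compound 1 differs from compound 2 in more than one place and its gap to compound 2 cannot be assigned to the side chain alone. On these data alone, how a morpholine or a piperidine at the end of the side chain, or a longer chain between the carbonyl and the amine, would read on the core of compound 2 is also open.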